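The source may report more compounds than this note shows. Statements on the series, on what has been measured and on what is new or still open speak of the compounds shown alone.

The measured compounds:

compound 1, `CCS(=O)(=O)Nc1ccc(NC(=O)c2ccc(Cl)cc2)cc1OC`: 60100 nM
compound 2, `CCS(=O)(=O)Nc1ccc(NC(=O)c2ccc(C#N)cc2)cc1OC`: 66400 nM
compound 3, `O=C(Nc1ccc(NS(=O)(=O)C(F)(F)F)c(F)c1)c1ccc(Cl)cc1`: 3270 nM

All three were tested in an ADME assay on RAW264.7 cells (Mus musculus) for cytotoxicity, read by MTT assay, with a stated time of 48 h; on this read-out lower numbers stand for stronger inhibition and higher numbers for weaker inhibition. Compound 1 and compound 2 share one core and differ in one place only: cyano in place of chloro on an aromatic carbon. That change gave a 1.1-fold higher number from compound 1 to compound 2 (0.04 log units; within the scatter). Compound 3 is built on a different core; how the two cores differ is not broken down here. In this assay compound 3 gives 3270 nM, the lowest of the three numbers, and its distance from compound 1 and from compound 2 lies beyond the usual scatter in both cases.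

Compound 4, `N#Cc1ccc(C(=O)Nc2ccc(NS(=O)(=O)C(F)(F)F)c(F)c2)cc1`, is not yet measured. It stands to compound 3 as compound 2 stands to compound 1: cyano in place of chloro on an aromatic carbon, the same change, at the same place, on the core of compound 3. Within the data shown here, the one earlier example of this change, from compound 1 to compound 2, stayed within the scatter. On that basis the step from compound 3 to compound 4 is expected to be small as well, a 1.1-fold higher number from compound 3 to compound 4 (0.04 log units; within the scatter). Compound 4 is therefore estimated at 3600 nM, with the likely range running from 1500 nM to 9000 nM.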

Compound 4, half-maximal inhibitory concentration: > 250000 nM
Compound 4 ended at the assay's limit; the forecaster's own chance of this, stated with the estimate: 5%; middle value at least 69-fold (1.84 log units) away from the limit.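

In this assay compound 4 gives > 250000 nM, which is a limit of the assay and not a number, and it is the only compound shown at that limit: the limit of > 250000 nM in this assay, at which 1 of the 4 values shown sits. On the core of the chloro compound, putting cyano in place of chloro gave an at least 76-fold higher number from compound 3 to compound 4 (1.88 log units; beyond the scatter), so the near-silent result of this change on the other core did not carry across: the same change on two cores in this assay, a 1.1-fold higher number (0.04 log units; within the scatter) from compound 1 to compound 2 and an at least 76-fold higher number (1.88 log units; beyond the scatter) from compound 3 to compound 4, at least 69-fold (1.84 log units) apart, beyond the scatter of two such steps. This rests on a single pair on each core, and it does not show which feature of the cores sets the two steps apart, nor how far compound 4 lies past the limit.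

The compounds shown leave open how other groups at this place, such as an amine or a carboxylic acid, would read on each core. They also leave open whether the same change on a third core would stay as small as on the first core or grow as large as on the second.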